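Trimming a Hydroxyalkyl Group on a Dehydrogenase Inhibitor

The source may report more compounds than this note shows. Statements on the series, on what has been measured and on what is new or still open speak of the compounds shown alone.

Compound 1 `CCC[S+]([O-])c1sc2nc(-c3cccs3)cc(C(=O)O)c2c1N` — 71 nM
Compound 2 `CCCC[S+]([O-])c1sc2nc(-c3nccs3)cc(-c3ccc(C(C)(C)O)cc3)c2c1N` — 3.6 nM
Compound 3 `CCCCS(=O)(=O)c1sc2nc(-c3nccs3)cc(-c3cnc(C)n3C)c2c1N` — 32 nM

In an assay for inhibition of 15-hydroxyprostaglandin dehydrogenase [NAD(+)] (Homo sapiens), read by fluorescence, with a stated time of 15 min, in the presence of a further agent that is not named here (on this read-out higher numbers stand for weaker inhibition and lower numbers for stronger inhibition), compound 2 gives the lowest number of the three; compound 3 stands above it by a margin beyond the usual scatter, and compound 1 further still. Compound 4 `CCCC[S+]([O-])c1sc2nc(-c3nccs3)cc(-c3ccc(CO)cc3)c2c1N` has not been measured. It differs from compound 2 in one place: hydroxymethyl in place of 1-hydroxy-1-methylethyl on an aromatic carbon. Among the measured compounds shown here, no pair of measured compounds shows this change, so compound 2 alone anchors the expectation. A step of modest size is expected, leaning toward weaker inhibition but quite possibly staying within the scatter: a 1.7-fold higher number from compound 2 to compound 4 (0.22 log units; within the scatter). Compound 4 is accordingly estimated at 6 nM, with a range from 2 nM to 20 nM.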

Compound 4, half-maximal inhibitory concentration: 2.5 nM
For compound 4 the middle estimate is 2.4-fold (0.38 log units) above the measured one; the range from low to high includes it.
By their numbers in this assay, from the lowest: compounds 4 and 2 (each within the scatter of the next); then compound 3; then compound 1.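

In this assay, replacing 1-hydroxy-1-methylethyl with hydroxymethyl gives a 1.4-fold lower number from compound 2 to compound 4 (0.16 log units; within the scatter), so at this place on the six-membered aromatic ring the read-out does not separate the two groups. The earlier compounds shown here could not show this, since none of them forms a pair differing in one place. No supporting data bear on the reason for this result. Still open, going by these compounds, is how a methoxy group, an amine or a carboxylic acid at this place would read, or a longer chain carrying the hydroxyl. Also open, on these data alone, is whether the same change would read alike on the cores of compound 1 or compound 3.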